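Adding a second chloro to the analog with the lowest number

A few compounds are considered here, and "the series" means these few. Any claim that something is new, unique, unknown or untested is made for them only; others in the source may bear on it.

Compound 1 `C/N=C(\S)n1nc(-c2ccccc2)nc1N`: 54%
Compound 2 `C/N=C(\S)n1nc(-c2ccc(C)cc2)nc1N`: 65%
Compound 3 `C/N=C(\S)n1nc(-c2ccccc2Cl)nc1N`: 18%

In a functional assay on the whole organism for inhibition, with Rattus norvegicus as the target, at a dose of 30 mg/kg (on this read-out higher numbers stand for more inhibition at the one dose given (going by the name of the read-out) and lower numbers for less inhibition), compound 3 stands lowest of the three numbers; compound 1 is the nearest, and compound 2 the furthest from it. Compound 4 `C/N=C(\S)n1nc(-c2ccc(Cl)cc2Cl)nc1N` has not yet been measured. It differs from compound 3 by chloro in place of hydrogen on an aromatic carbon. Within the data shown here, the one measured step that bears on this change is a number 36 percentage points lower from compound 1 to compound 3 (beyond the scatter), a large fall when a chloro group entered the ring. The other step, a number 11 percentage points higher from compound 1 to compound 2 (beyond the scatter), concerned a methyl group and rose modestly. Since compound 3 already sits low, the expected step in this assay is a small further fall, a number 4 percentage points lower from compound 3 to compound 4 (within the scatter), not beyond the scatter. Compound 4 is therefore estimated at 14%, within 0% to 40%.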

Compound 4, a percentage reported as inhibition, in the whole organism at one dose (the size of the read-out at that dose, not a potency): 91%
For compound 4 the middle estimate is 77 percentage points below the measured one; the measured number lies above the stated range.
By their numbers in this assay, from the lowest: compound 3; then compound 1; then compound 2; then compound 4.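

In this assay, the step of a number 73 percentage points higher from compound 3 to compound 4 (beyond the scatter) shows that chloro in place of hydrogen on an aromatic carbon has no fixed direction in this series. The same kind of change gave a number 36 percentage points lower from compound 1 to compound 3 (beyond the scatter), yet here, with the entering chloro meta to a chloro group and para to a large group, the number rises. The data offer no explanation for this reversal. They leave open whether the rise needs the first chloro group, or would come with a single chloro at this place, and whether a methoxy group or an amine there would give a similar number.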